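Swapping the Halogen on a Chalcone-Linked Lactone Amide

A few compounds are considered here, and "the series" means these few. Any claim that something is new, unique, unknown or untested is made for them only; others in the source may bear on it.

Compound 1, `O=C(COc1ccc(C(=O)/C=C/c2ccccc2Br)cc1)N[C@H]1CCOC1=O`, carries a chalcone arm ending in a 2-bromophenyl group and a lactone amide tail. Among the measured compounds shown here, in a functional assay on MGC-803 cells (Homo sapiens) for antiproliferative activity, read by MTT assay, with a stated time of 72 h (a higher number here means a weaker inhibitor, a lower number a stronger inhibitor), compound 1 gives 12200 nM, the only number among the three measured members of this set. Compound 2, `O=C(CNc1ccccc1Cl)N[C@H]1CCOC1=O`, reaches only a limit in this assay, at > 64000 nM. Compound 3, `O=C(CNc1cccc(Cl)c1)N[C@H]1CCOC1=O`, likewise shows a limit of > 64000 nM in this assay. For the measured compounds named here, those two limits are summarised as the limit of > 64000 nM in this assay, at which 2 of the 3 values shown sit, so compound 1 stands alone as the one compound with a measurable number, and no step between measured compounds that differ in a single place is available.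

Compound 4, `O=C(COc1ccc(C(=O)/C=C/c2cccc(F)c2)cc1)N[C@H]1CCOC1=O`, has not yet been measured. It differs from compound 1 by 3-fluorophenyl in place of 2-bromophenyl on a double-bonded chain carbon bound to a double-bonded chain carbon. Going by the values given here, with no measured step of this kind to lean on, the expectation is a change within the usual scatter, in either direction, so that the step from compound 1 to compound 4 is estimated as a 1.0-fold lower number from compound 1 to compound 4 (0.01 log units; within the scatter). Compound 4 is therefore expected to give about 12000 nM in this assay, within a range of 4000 nM to 40000 nM.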

Compound 4, half-maximal inhibitory concentration: > 64000 nM
Compound 4: only a limit was reported (the forecaster's own chance of this, stated with the estimate: 15%); middle value at least 5.3-fold (0.72 log units) from the limit.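

In this assay, the end group of the chalcone arm proves to matter: 3-fluorophenyl in place of 2-bromophenyl, on a double-bonded chain carbon bound to a double-bonded chain carbon, gives an at least 5.2-fold higher number from compound 1 to compound 4 (0.71 log units; beyond the scatter). Until now compound 1 had no measured partner differing in one place, so nothing showed how much its number depended on this group, and the chalcone arm alone clearly does not guarantee a measurable value. On these data alone, the result for compound 4 is a limit of the assay and not a number, so the full size of the step is unknown, and this limit is now the most common reading in the set: the limit of > 64000 nM in this assay, at which 3 of the 4 values shown sit.

Because the halogen and its numbered place change together, the compounds shown cannot separate the two. A 2-fluorophenyl or 3-bromophenyl group would pull them apart, while an aminophenyl group would test a different kind of substituent at this place.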